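Working notes: the step from compound 2 to compound 3

The compounds below may be only part of what the source reports. "The series", "measured", "known", "first", "only" and "open" are said of these compounds alone.

Measured in an ADME assay on MT4 cells (Homo sapiens) for cytotoxicity, read by MTT assay, with a stated time of 5 days; on this read-out higher numbers stand for lower toxicity in this test and lower numbers for higher toxicity in this test
- compound 1 `Cc1cc(C)cc(S(=O)(=O)n2c(SCC(=O)Nc3ccc(C(=O)O)cc3)nc3ccccc32)c1` gives 115000 nM
- compound 2 `COC(=O)c1ccc(NC(=O)CSc2nc3ccccc3n2S(=O)(=O)c2cc(C)cc(C)c2)cc1` gives 10000 nM

For the measured compounds named here, compound 2 at 10000 nM holds the lower of the two numbers in this assay and has compound 1 as its only neighbour. The next structure is compound 3 `Cc1cc(C)cc(S(=O)(=O)n2c(SCC(=O)Nc3ccccc3Cl)nc3ccccc32)c1` with the difference 2-chlorophenyl in place of 4-(methoxycarbonyl)phenyl on an amide-type nitrogen in the series, that is, 2-chlorophenyl in place of 4-(methoxycarbonyl)phenyl on an amide-type nitrogen. Going by the values given here, one measured step bears on this, namely a 12-fold lower number from compound 1 to compound 2 (1.06 log units; beyond the scatter) at the end of the group that now leaves. It is large and shows that this part of the structure can move the number. The hydrogen on oxygen in compound 1 is absent from compound 3 as it is from compound 2, so compound 2 is the closer reference. Among the compounds with values here, no measured compound carries 2-chlorophenyl, so the direction stays open and the range is wide. No change beyond the scatter is expected, and the estimated move is a 1.2-fold higher number from compound 2 to compound 3 (0.08 log units; within the scatter) as a working figure. The estimate for compound 3 is 12000 nM with an expected range of 3500 nM to 50000 nM in this series.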

Compound 3, half-maximal cytotoxic concentration: 107000 nM
Compound 3: the middle estimate sits 8.9-fold (0.95 log units) below what was measured, outside the stated range (above it).
By their numbers in this assay, from the lowest: compound 2; then compounds 3 and 1 (each within the scatter of the next).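

In this assay, the change on the amide-type nitrogen gives an 11-fold higher number from compound 2 to compound 3 (1.03 log units; beyond the scatter), so the low number of compound 2 is not shared by every aryl group at this place, and a ring carrying neither the methyl ester nor the carboxylic acid can stand at the higher level. The other comparison, a 1.1-fold lower number from compound 1 to compound 3 (0.03 log units; within the scatter), puts 2-chlorophenyl and 4-carboxyphenyl level within the scatter, leaving compound 2 alone at the low end of the three, with its steps to both other compounds beyond the scatter. No evidence is available to explain the low number of compound 2 or the return to the higher level with 2-chlorophenyl.

The step from compound 2 to compound 3 changes the substituent and its place on the ring together, so the compounds shown do not separate what each contributes. An unsubstituted phenyl on the same nitrogen would bear on this, and an ethyl ester or a primary amide in place of the methyl ester would show whether the low number extends beyond the methyl ester of compound 2.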